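Exchanging the Aryl Group: Nitrile for Nitro

The compounds below may be only part of what the source reports. "The series", "measured", "known", "first", "only" and "open" are said of these compounds alone.

Compound 1, `C[C@H]1CC[C@@H]2[C@@H](OC(=O)[C@]23CC(c2c(Cl)cccc2Cl)=NO3)[C@]2(C)C(=O)C=C[C@@]12O`: 38000 nM
Compound 2, `C[C@H]1CC[C@@H]2[C@@H](OC(=O)[C@]23CC(c2cccc([N+](=O)[O-])c2)=NO3)[C@]2(C)C(=O)C=C[C@@]12O`: 51000 nM

In a functional assay on DU-145 cells (Homo sapiens) for cytotoxicity, read by sulforhodamine B assay, with a stated time of 48 h (a lower number here means a stronger inhibitor, a higher number a weaker inhibitor), compound 1 gives 38000 nM and compound 2 gives 51000 nM. Compound 2 shows the higher of the two numbers, but the gap to compound 1 is within the scatter, so the two cannot be told apart: a 1.3-fold higher number from compound 1 to compound 2 (0.13 log units; within the scatter).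

Compound 3, `C[C@H]1CC[C@@H]2[C@@H](OC(=O)[C@]23CC(c2ccc(C#N)cc2)=NO3)[C@]2(C)C(=O)C=C[C@@]12O`, has not yet been measured. It differs from compound 2 in one place: 4-cyanophenyl in place of 3-nitrophenyl on a carbon with a double bond to nitrogen. For the measured compounds named here, the only measured step that bears on this change is the earlier exchange of one aryl group for another on the same carbon, a 1.3-fold higher number from compound 1 to compound 2 (0.13 log units; within the scatter), which stayed within the scatter. Going by the values given here, no other step is available, so the step to compound 3 is expected to be a 1.1-fold lower number from compound 2 to compound 3 (0.05 log units; within the scatter), with nothing beyond the scatter. Compound 3 is therefore estimated at 45000 nM, within a range from 20000 nM to 100000 nM.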

Compound 3, half-maximal inhibitory concentration: 26000 nM
Compound 3: the middle estimate sits 1.7-fold (0.24 log units) above what was measured, and the stated range covers the measured number.
By their numbers in this assay, from the lowest: compounds 3, 1 and 2 (each within the scatter of the next).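

In this assay, 4-cyanophenyl on the carbon with a double bond to nitrogen also stays within the scatter of both earlier aryl groups: the exchange for 3-nitrophenyl gives a 2.0-fold lower number from compound 2 to compound 3 (0.29 log units; within the scatter) and the exchange for 2,6-dichlorophenyl gives a 1.5-fold lower number from compound 1 to compound 3 (0.16 log units; within the scatter) at this same place. Taken with the earlier pair, this means that the three aryl groups cannot be told apart here, so the compounds give no ranking of them. No measurement on these compounds offers an explanation for this result.

All three groups shown are substituted phenyl rings. On these data alone, it remains open whether a group of another kind on this carbon, such as a longer alkyl chain, or a phenyl ring bearing an amine or a carboxylic acid, would move the number beyond the scatter.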